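The compounds below may be only part of what the source reports. "The series", "measured", "known", "first", "only" and "open" are said of these compounds alone.

Two measured compounds frame this step. Compound 1, `COc1ccc2nc(Nc3nc(Nc4ccc(S(C)(=O)=O)cc4)ncc3F)sc2c1`, in a functional assay on MCF7 cells (Homo sapiens) for antiproliferative activity, read by MTT assay, with a stated time of 48 h (on this read-out lower numbers stand for stronger inhibition and higher numbers for weaker inhibition), gives 5850 nM. Compound 2, `CS(=O)(=O)c1ccc(Nc2nccc(Nc3nc4ccc(Cl)cc4s3)n2)cc1`, differs from it in more than one place. In this assay compound 2 reaches only a limit of the assay, > 50000 nM. That limit is the limit of > 50000 nM in this assay, at which 1 of the 2 values shown sits. The unmeasured compound 3, `COc1ccc2nc(Nc3ccnc(Nc4ccc(S(C)(=O)=O)cc4)n3)sc2c1`, is reached from compound 2 by a single change: methoxy in place of chloro on an aromatic carbon. For the measured compounds named here, no measured pair shows this change on its own, so its size cannot be read off. Compound 1 carries the same methoxy group and has a measured number, while compound 2 with the chloro sits at the limit; the two also differ elsewhere, so only their two values can be set side by side. The step expected here is an at least 1.6-fold lower number from compound 2 to compound 3 (0.22 log units; that floor lies within the scatter), a move toward stronger inhibition, though whether it goes beyond the scatter is open. Compound 3 is therefore estimated at 30000 nM, with a range from 8000 nM to 100000 nM, and a fair chance that the assay again reports only a limit.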

Compound 3, half-maximal inhibitory concentration: > 50000 nM
Compound 3 gave a limit, no number; the forecaster's own chance of this, stated with the estimate: 40%; middle value at least 1.6-fold (0.22 log units) from the limit.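

In this assay, compound 3 gives only a limit, just as compound 2 does, so putting methoxy in place of chloro at this position does not by itself produce a measurable number. The size of that change cannot be read, because both compounds sit at the same limit: the limit of > 50000 nM in this assay, at which 2 of the 3 values shown sit. The new information comes from the pair of compound 1 and compound 3, which differ only by hydrogen in place of fluoro on an aromatic carbon: this single change gives an at least 8.5-fold higher number from compound 1 to compound 3 (0.93 log units; beyond the scatter), a move toward weaker inhibition, which shows that methoxy alone does not account for the measured number of compound 1.

Going by these compounds, a chloro compound that also carries the fluoro would allow chloro and methoxy to be compared directly at this position, so whether the two groups differ at all remains open. On these data alone, it is also open how an amine or a longer chain such as ethoxy would behave on the same aromatic carbon, and whether the benefit of the fluoro holds with those groups in place.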